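The compounds below may be only part of what the source reports. "The series", "measured", "known", "first", "only" and "open" are said of these compounds alone.

Compound 1, `CCOC(=O)CCCn1c2ccc([N+](=O)[O-])cc2c(=O)n1Cc1ccccc1`, gives 78100 nM in an ADME assay on L929 cells (Mus musculus) for cytotoxicity, read by resazurin assay, with a stated time of 48 h; a lower number here means that less compound is tolerated, a higher number that more compound is tolerated. Compound 2, `O=c1c2cc([N+](=O)[O-])ccc2n(CCO)n1Cc1ccccc1`, differs from it by hydroxy in place of (ethoxycarbonyl)methyl on a saturated chain carbon, two bonds along the chain from an aromatic nitrogen. In this assay compound 2 reaches only a limit of the assay, > 256000 nM, so the step of an at least 3.2-fold higher number from compound 1 to compound 2 (0.51 log units; beyond the scatter) is itself bounded by that limit. Compound 3, `CCOC(=O)CCCOc1c2cc([N+](=O)[O-])ccc2nn1Cc1ccccc1`, is built from the same atoms as compound 1 joined differently; the difference between the two cores is not broken down here. In this assay compound 3 likewise reports only a limit, > 256000 nM. Compound 4, `O=[N+]([O-])c1ccc2nn(Cc3ccccc3)c(OCCO)c2c1`, has not been measured yet; it differs from compound 3 by hydroxy in place of (ethoxycarbonyl)methyl on a saturated chain carbon, two bonds along the chain from an oxygen on an aromatic ring. This is the same kind of change as from compound 1 to compound 2, but the chain carbon now sits two bonds along the chain from an oxygen on an aromatic ring rather than from an aromatic nitrogen. That earlier change moved the number by an at least 3.2-fold higher number from compound 1 to compound 2 (0.51 log units; beyond the scatter), while the new one begins from a compound already at the limit of > 256000 nM in this assay, at which 2 of the 3 values shown sit. Compound 4 is therefore expected to remain at or past that ceiling, around 300000 nM (between 120000 nM and 1000000 nM), an expected step that the limit leaves unreadable from compound 3 to compound 4, most likely reported again as a limit rather than a number.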

Compound 4, concentration lethal to 50% of the cells: > 256000 nM
Compound 4 ended at the assay's limit; the forecaster's own chance of this, stated with the estimate: 85%; the middle value lies beyond the limit too.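

In this assay no size can be read for the step between compound 3 and compound 4, because both report only a limit and not a number: the limit of > 256000 nM in this assay, at which 3 of the 4 values shown sit.
The compounds shown leave open how far compound 2, compound 3 and compound 4 actually lie past that limit, and whether replacing 3-(ethoxycarbonyl)propoxy with 2-hydroxyethoxy changes the number at all.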